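A few compounds are considered here, and "the series" means these few. Any claim that something is new, unique, unknown or untested is made for them only; others in the source may bear on it.

Series notes, values from an ADME assay on BAEC cells (Bos taurus) for cytotoxicity, read by MTT assay, with a stated time of 2 days; a higher number here means a weaker inhibitor, a lower number a stronger inhibitor:

- Compound 1 `COc1c(Br)cc(C=O)c(OCc2ccccc2)c1Br`: > 12500 nM (a limit)
- Compound 2 `COc1c(Br)cc(CO)c(OCc2ccccc2)c1Br`: > 12000 nM (a limit)

Compound 2 stands at > 12000 nM, which is a limit and not a number. Compound 1 gives > 12500 nM, which is also a limit. No numeric value is therefore available in this assay for either compound.

The next compound is compound 3 `COc1c(Br)cc(CO)c(OCCO)c1Br`. The change is hydroxymethyl in place of phenyl on a saturated chain carbon bound to an oxygen on an aromatic ring.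

Among the measured compounds shown here, the only measured step is a step that the two limits leave unreadable from compound 1 to compound 2. It concerns a different place on the shared core, and its size cannot be read, so it gives no size or direction for the present change. For the measured compounds named here, no measured step covers the loss of the phenyl. No step beyond the scatter is therefore expected in this assay, and no direction is favoured. A further limit is the most likely result.

For compound 3 the estimated value is 15000 nM, with an expected range from 8000 nM to 30000 nM. The estimated step is a step that the limit leaves unreadable from compound 2 to compound 3.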

Compound 3, half-maximal inhibitory concentration: > 28000 nM
Compound 3 ended at the assay's limit; the forecaster's own chance of this, stated with the estimate: 85%; middle value at least 1.8-fold (0.27 log units) from the limit.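

In this assay compound 3 gives > 28000 nM, a limit and not a number. Compound 2 also stands only at a limit, so no new step can be read between compound 2 and compound 3. The compounds shown leave open where compound 1, compound 2 and compound 3 would fall as numbers in this assay, and what size of step hydroxymethyl in place of phenyl gives there.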